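Removing a methyl from a phenol hydrazone

A few compounds are considered here, and "the series" means these few. Any claim that something is new, unique, unknown or untested is made for them only; others in the source may bear on it.

Compound 1 `O=[N+]([O-])c1ccc(O)c(/C=N/Nc2nc3ccccc3s2)c1` gives 1650 nM in a functional assay on HL-60 cells (Homo sapiens) for cytotoxicity, read by MTT assay, with a stated time of 72 h; a higher number here means a weaker inhibitor, a lower number a stronger inhibitor. Compound 2 `COc1cc(/C=N/Nc2nc3ccccc3s2)ccc1O` gives > 16700 nM in this assay, which is a limit of the assay rather than a measured number.

Among the compounds with values here, compound 2 therefore stands at the limit of > 16700 nM in this assay, at which 1 of the 2 values shown sits; no single number places it against compound 1, and no step between the two measured compounds is given. Compound 3 `Oc1ccc(/C=N/Nc2nc3ccccc3s2)cc1O` has not yet been measured. It differs from compound 2 only by hydrogen in place of methyl on an oxygen on an aromatic ring, so the methoxy group of compound 2 becomes a hydroxy group in compound 3.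

Because compound 2 sits at the limit of > 16700 nM in this assay, at which 1 of the 2 values shown sits, the size of the change cannot be read from the data. The step from compound 2 to compound 3 is expected to be an at least 2.0-fold lower number from compound 2 to compound 3 (0.31 log units; beyond the scatter), that is towards a somewhat stronger inhibitor but with wide uncertainty. Compound 3 is estimated at 8000 nM in this assay, within 2000 nM to 30000 nM.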

Compound 3, half-maximal inhibitory concentration: 13600 nM
Estimate against measurement, compound 3: 1.7-fold (0.23 log units) below, within the range that was stated.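

Within the data shown here, compound 3 gives this change from methoxy to hydroxy, on an oxygen on an aromatic ring, a measured number on one side for the first time. In this assay the result is an at least 1.2-fold lower number from compound 2 to compound 3 (0.08 log units; that floor lies within the scatter), so swapping methyl for hydrogen here cannot yet be said to change the read-out by more than ordinary scatter. Compound 2 carries a limit of the assay and not a number, and the true size of the step stays unknown because of it: the limit of > 16700 nM in this assay, at which 1 of the 3 values shown sits.

The compounds shown leave open how a longer chain, such as ethyl or propyl, would read in place of the methyl on this oxygen. They also leave open whether an amine in place of the hydroxy group would give a different value.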